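The source may hold more compounds than are shown below. What is called first, only, known or untested is meant among the compounds shown, and "the series" means these compounds.

Measured so far in a functional assay on OVCAR-3 cells (Homo sapiens) for antiproliferative activity, read by MTT assay, with a stated time of 24 h; on this read-out higher numbers stand for weaker inhibition and lower numbers for stronger inhibition:

- Compound 1 `Cc1ccccc1NNC(=O)c1ccc(NS(=O)(=O)c2cnc(O)nc2O)cc1`: > 20000 nM
- Compound 2 `Cc1cccc(NNC(=O)c2cccc(NS(=O)(=O)c3cnc(O)nc3O)c2)c1`: > 20000 nM
- Compound 3 `Cc1ccccc1NNC(=O)c1ccccc1NS(=O)(=O)c1cnc(O)nc1O`: > 20000 nM

Each of these entries is a limit of this assay and not a number. The account follows compound 3, which gives > 20000 nM, a limit. The two other compounds share that position, and the whole picture so far is the limit of > 20000 nM in this assay, at which 3 of the 3 values shown sit. Going by the values given here, no pair of measured compounds differing in one place is available, so no measured step can serve as a guide.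

Compound 4 `Cc1cccc(NNC(=O)c2ccccc2NS(=O)(=O)c2cnc(O)nc2O)c1` has the same atoms as compound 3, joined differently, with 3-methylphenyl in place of 2-methylphenyl on an amine nitrogen. No step beyond the usual scatter is expected in this assay, and no direction is favoured. This expectation rests on compound 3, whose > 20000 nM is a limit. The estimated step is a step that the limit leaves unreadable from compound 3 to compound 4, and it should be read as a rough expected figure set against a limit. The most likely outcome is that compound 4 also returns only a limit. Should a number appear, the estimate for compound 4 is 25000 nM, with an expected range of 10000 nM to 50000 nM.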

Compound 4, half-maximal inhibitory concentration: > 20000 nM
Compound 4 gave a limit, no number; the forecaster's own chance of this, stated with the estimate: 85%; the middle value is on the limit's open side.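

In this assay compound 4 gives > 20000 nM and this is a limit. Going by these compounds alone, compound 3 also stands at a limit, so no step between compound 3 and compound 4 can be read. The compounds shown leave open how 2-methylphenyl and 3-methylphenyl compare, and what could bring a number in this assay within reach. The picture is unchanged: the limit of > 20000 nM in this assay, at which 4 of the 4 values shown sit.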